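The compounds below may be only part of what the source reports. "The series", "measured", "known", "first", "only" and "open" are said of these compounds alone.

Measured in an ADME assay on MT4 cells (Homo sapiens) for cytotoxicity, read by MTT assay; on this read-out lower numbers stand for higher toxicity in this test and higher numbers for lower toxicity in this test:
- Compound 1 `Cc1cc(C)cc(S(=O)(=O)c2c(C(=O)NCC(=O)NCc3ccncc3)[nH]c3ccc(Cl)cc23)c1`: > 48900 nM, a limit of the assay
- Compound 2 `Cc1cc(C)cc(S(=O)(=O)c2c(C(=O)Nc3ccnc(C#N)c3)[nH]c3ccc(Cl)cc23)c1`: 6840 nM
- Compound 3 `Cc1cc(C)cc(S(=O)(=O)c2c(C(=O)NCC(=O)NC(C)c3ccncc3)[nH]c3ccc(Cl)cc23)c1`: 47000 nM

Not yet measured: compound 4 `Cc1cc(C)cc(S(=O)(=O)c2c(C(=O)NCC(=O)NCc3ccncn3)[nH]c3ccc(Cl)cc23)c1`.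

Compound 3 has the higher of the two exact numbers, 47000 nM. The gap to the other exact number is a 6.9-fold higher number from compound 2 to compound 3 (0.84 log units; beyond the scatter).

The next change is (pyrimidin-4-yl)methyl in place of 1-(pyridin-4-yl)ethyl on an amide-type nitrogen. In words, it puts (pyrimidin-4-yl)methyl in place of 1-(pyridin-4-yl)ethyl on an amide-type nitrogen.

The closest measured step is an at least 1.0-fold lower number from compound 1 to compound 3 (0.01 log units; that floor lies within the scatter), which adds a methyl on the chain carbon. The larger at least 7.1-fold lower number from compound 1 to compound 2 (0.85 log units; beyond the scatter) replaces the whole chain, a different kind of change. Among the measured compounds shown here, no measured step swaps the ring itself.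

No shift beyond the scatter is therefore expected, and the estimated step is a 1.1-fold lower number from compound 3 to compound 4 (0.05 log units; within the scatter).

Compound 4 is expected near 42000 nM, with an estimated range of 18000 nM to 60000 nM.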

Compound 4, half-maximal cytotoxic concentration: > 48800 nM
Compound 4 ended at the assay's limit; the forecaster's own chance of this, stated with the estimate: 55%; middle value at least 1.1-fold (0.06 log units) from the limit.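

In this assay compound 4 gives > 48800 nM, which is a limit of the assay. Putting (pyrimidin-4-yl)methyl in place of 1-(pyridin-4-yl)ethyl changes the ring and removes the chain methyl together, yet it gives an at least 1.0-fold higher number from compound 3 to compound 4 (0.01 log units; that floor lies within the scatter), so this change brings no readable move towards higher toxicity in this test. The chain-bearing compound 4 also keeps its distance from the 2-cyanopyridin-4-yl amide, with an at least 7.1-fold higher number from compound 2 to compound 4 (0.85 log units; beyond the scatter).

The step between compound 1 and compound 4 cannot be read, as both ends are limits. Going by these compounds, whether an amine or a carboxylic acid on this ring, or a longer chain, would keep the numbers this high stays open.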